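The source may hold more compounds than are shown below. What is called first, only, known or untested is meant among the compounds shown, and "the series" means these compounds.

Compound 1, `CC(C)(C)OC(=O)NCCCCNC(=O)CN1CN(c2ccccc2)C2(CCN(C(=O)c3ccc(C(C)(C)C)cc3)CC2)C1=O`, shares its core with the other compounds described here, but in an assay on HEK293 cells for displacement of a labelled ligand from NPC1-like intracellular cholesterol transporter 1 (Homo sapiens) (a higher number here means a weaker inhibitor, a lower number a stronger inhibitor), compound 1 gives "not determined" (no result reported), so it cannot serve as a reference point. Two compounds do carry numbers. Compound 2, `CC(C)(C)c1ccc(C(=O)N2CCC3(CC2)C(=O)N(CC(=O)N2CCCC(O)C2)CN3c2ccccc2)cc1`, gives 12200 nM in this assay. For the measured compounds named here, compound 3, `CC(C)(C)c1ccc(C(=O)N2CCC3(CC2)C(=O)N(CC(=O)NCNS(C)(=O)=O)CN3c2ccccc2)cc1`, gives 3200 nM in this assay, which is the lower of the two numbers measured, with compound 2 the only neighbour: the step was a 3.8-fold lower number from compound 2 to compound 3 (0.58 log units; beyond the scatter), where ((methanesulfonamido)methyl)amino replaced 3-hydroxypiperidin-1-yl on a carbonyl carbon.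

Compound 4, `CC(C)(C)c1ccc(C(=O)N2CCC3(CC2)C(=O)N(CC(=O)NCN)CN3c2ccccc2)cc1`, differs from compound 3 by a smaller change: hydrogen in place of methylsulfonyl on an amine nitrogen. Going by the values given here, the one measured step exchanged the whole group on that carbonyl carbon and so does not test this particular cut; no pair of measured compounds isolates the methylsulfonyl. The expectation therefore rests only on compound 3 as the nearest neighbour. The most defensible expectation is a step of a 1.9-fold higher number from compound 3 to compound 4 (0.27 log units; within the scatter), a shift toward a higher number that stays within the usual scatter, with wide uncertainty in both directions. For compound 4 the estimate in this assay is 6000 nM, with a range from 2000 nM to 25000 nM.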

Compound 4, half-maximal inhibitory concentration: 26500 nM
For compound 4 the middle estimate is 4.4-fold (0.65 log units) below the measured one, and the stated range ends below it.
By their numbers in this assay, from the lowest: compound 3; then compound 2; then compound 4.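

In this assay, for the compounds shown here, putting hydrogen in place of methylsulfonyl on the amine nitrogen gives an 8.3-fold higher number from compound 3 to compound 4 (0.92 log units; beyond the scatter), the first comparison here that isolates this one group, and it shows that the lower number of compound 3 depends on the methylsulfonyl and not just on the chain that carries it. The second comparison, a 2.2-fold higher number from compound 2 to compound 4 (0.34 log units; beyond the scatter), shows that the bare (aminomethyl)amino group on the carbonyl carbon does not repeat the gain over compound 2 seen with ((methanesulfonamido)methyl)amino; once the methylsulfonyl is gone, the order relative to compound 2 reverses. Going by these compounds alone, nothing available here explains why removing this group moves the number so far.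

From the compounds shown here alone, whether the effect is specific to methylsulfonyl remains open, since an acetyl or a phenylsulfonyl group on the same nitrogen could tell a sulfonyl requirement from a general need for something larger than hydrogen. It is also unknown how a longer chain in place of the aminomethyl link would change the number, with the methylsulfonyl kept at its end.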